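The source may report more compounds than this note shows. Statements on the series, on what has been measured and on what is new or still open speak of the compounds shown alone.

In a functional assay, read by Griess assay, with a stated time of 2.5 h (on this read-out higher numbers stand for weaker inhibition and lower numbers for stronger inhibition), compound 1 `COc1cc(OC)c(OC)cc1/C=C/C(=O)c1ccccc1` gives 2.01 ug/mL, compound 2 `COc1cc(OC)c(OC)cc1/C=C/C(=O)c1ccc(O)cc1O` gives 2.76 ug/mL and compound 3 `COc1cc(OC)c(OC)cc1/C=C/C(=O)c1ccc(F)cc1` gives 1.96 ug/mL. Compound 3 sits level with both others, with a 1.4-fold lower number from compound 2 to compound 3 (0.15 log units; within the scatter) also inside the scatter. Compound 4 `COc1cc(OC)c(OC)cc1/C=C/C(=O)c1ccc(Br)cc1` differs from compound 3 by bromo in place of fluoro on an aromatic carbon, para to a large group. Among the compounds with values here, no bromo compound has been measured. The closest measured change is fluoro in place of hydrogen on an aromatic carbon, a 1.0-fold lower number from compound 1 to compound 3 (0.01 log units; within the scatter). The larger change, 2,4-dihydroxyphenyl in place of phenyl, gives a 1.4-fold higher number from compound 1 to compound 2 (0.14 log units; within the scatter). On these two steps, no change beyond the scatter is expected in this assay. The estimated step is a 1.0-fold higher number from compound 3 to compound 4 (0.01 log units; within the scatter). For compound 4 the estimated value is 2 ug/mL, with an expected range from 1.2 ug/mL to 3.4 ug/mL.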

Compound 4, half-maximal inhibitory concentration: 2.22 ug/mL
Compound 4: middle estimate off by 1.1-fold (0.05 log units), on the low side; measured number inside the range.
By their numbers in this assay, from the lowest: compounds 3, 1, 4 and 2 (each within the scatter of the next).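

In this assay, bromo on this aromatic carbon, para to a large group, stays level with fluoro (a 1.1-fold higher number from compound 3 to compound 4 (0.05 log units; within the scatter)) and with hydrogen (a 1.1-fold higher number from compound 1 to compound 4 (0.04 log units; within the scatter)), so a second halogen at this position also produces no step beyond the scatter. The 4-bromophenyl group likewise stays level with the 2,4-dihydroxyphenyl group (a 1.2-fold lower number from compound 2 to compound 4 (0.09 log units; within the scatter)). No available evidence accounts for this flat result. On these data alone, whether an amine or a carboxylic acid at this position would move the number beyond the scatter remains open. Changes to the shared core also remain untested here.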